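Expected step from trimethoxyphenyl to methoxyphenyl at compound 4

A few compounds are considered here, and "the series" means these few. Any claim that something is new, unique, unknown or untested is made for them only; others in the source may bear on it.

Measured values in a functional assay on A549 cells (Homo sapiens) for cytotoxicity, read by MTT assay, with a stated time of 72 h (a lower number here means a stronger inhibitor, a higher number a weaker inhibitor), are as follows:
Compound 1 `O=C(/C=C/c1ccc([N+](=O)[O-])cc1)Nc1cc2c(Nc3ccc(F)c(Cl)c3)ncnc2cc1O[C@H]1CCOC1` gives 12000 nM
Compound 2 `COc1ccc(/C=C/C(=O)Nc2cc3c(Nc4ccc(F)c(Cl)c4)ncnc3cc2O[C@H]2CCOC2)c(OC)c1` gives 9350 nM
Compound 3 `COc1ccc(/C=C/C(=O)Nc2cc3c(Nc4ccc(F)c(Cl)c4)ncnc3cc2O[C@H]2CCOC2)c(OC)c1OC` gives 70 nM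

Compound 3 has the lowest number of the three: the measured steps to it are a 130-fold lower number from compound 2 to compound 3 (2.13 log units; beyond the scatter) and a 170-fold lower number from compound 1 to compound 3 (2.23 log units; beyond the scatter) and both are large. Compound 4 `COc1ccc(/C=C/C(=O)Nc2cc3c(Nc4ccc(F)c(Cl)c4)ncnc3cc2O[C@H]2CCOC2)cc1` carries 4-methoxyphenyl in place of 2,3,4-trimethoxyphenyl on a double-bonded chain carbon bound to a double-bonded chain carbon. For the measured compounds named here, the remaining step, a 1.3-fold lower number from compound 1 to compound 2 (0.11 log units; within the scatter), stays within the scatter, so only compound 3 has given a low number so far. Compound 4 lacks the 2,3,4-trimethoxyphenyl, so a large step to a higher number is expected in this assay and a value near those of compounds 1 and 2 seems likely. Going by the values given here, no measured compound carries 4-methoxyphenyl, so this remains uncertain. For compound 4 the estimated step is an 86-fold higher number from compound 3 to compound 4 (1.93 log units; beyond the scatter) in size. For compound 4 the estimated value is 6000 nM within an expected range from 1000 nM to 20000 nM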

Compound 4, half-maximal inhibitory concentration: 3050 nM
Compound 4: the middle estimate sits 2.0-fold (0.29 log units) above what was measured, within the range that was stated.
By their numbers in this assay, from the lowest: compound 3; then compound 4; then compounds 2 and 1 (each within the scatter of the next).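

In this assay the 2,3,4-trimethoxyphenyl on a double-bonded chain carbon bound to a double-bonded chain carbon cannot give way to 4-methoxyphenyl without a large rise (a 44-fold higher number from compound 3 to compound 4 (1.64 log units; beyond the scatter)). The 4-methoxyphenyl nevertheless gives modestly lower numbers than 2,4-dimethoxyphenyl (a 3.1-fold lower number from compound 2 to compound 4 (0.49 log units; beyond the scatter)) and 4-nitrophenyl (a 3.9-fold lower number from compound 1 to compound 4 (0.59 log units; beyond the scatter)), so the number does not fall steadily as methoxy groups are added: compound 2 goes against such a trend, and the sharp drop appears only with compound 3. Nothing at hand accounts for these steps.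

Open, on these data alone, is whether a hydroxyl or an amine in place of a methoxy on an aromatic carbon would keep the low number of compound 3. Also open, as far as these compounds go, is whether this pattern holds on any core other than the shared core.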